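Binding: shorter chain with a hydroxypiperidine head

This account rests on a few compounds, and the source may have more. Where it says the series, first, only, none or still open, it means among the compounds named here.

Measured so far:
compound 1 `O=c1cc(-c2ccccc2)oc2cccc(OCCCCCCCN3CCC(O)CC3)c12` — in an assay on isolated protein (Cavia porcellus) with Sigma non-opioid intracellular receptor 1 (Homo sapiens) as the target, read by radioligand binding (a higher number here means a weaker inhibitor, a lower number a stronger inhibitor), compound 1 gives 65 nM
compound 2 `CN(C)CCCCCCOc1ccc2oc(-c3ccccc3)cc(=O)c2c1` — compound 2 gives 335 nM
compound 3 `CN(C)CCCCCCCOc1ccc2oc(-c3ccccc3)cc(=O)c2c1` — compound 3 gives 188 nM

Compound 2 stands at the highest number of the three. Its nearest neighbour is compound 3, a 1.8-fold lower number from compound 2 to compound 3 (0.25 log units; within the scatter). Compound 1 lies further off, at 65 nM. Compound 2 stands at 335 nM, a gap beyond the scatter.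

Compound 4 `O=c1cc(-c2ccccc2)oc2ccc(OCCCN3CCC(O)CC3)cc12` differs from compound 2 in one place: 4-hydroxypiperidin-1-yl in place of 3-(dimethylamino)propyl on a saturated chain carbon, three bonds along the chain from an oxygen on an aromatic ring. For the measured compounds named here, the only measured step, from compound 2 to compound 3, concerns chain length alone and stays within the scatter; no measured step isolates the change of amine. Going by the values given here, the values of compound 1 and compound 2 are the sole guide. A step in this assay a 2.2-fold lower number from compound 2 to compound 4 (0.35 log units; beyond the scatter) is therefore expected, downward but uncertain. Compound 4 is estimated at 150 nM, between 40 nM and 600 nM.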

Compound 4, half-maximal inhibitory concentration: 123 nM
For compound 4 the middle estimate is 1.2-fold (0.09 log units) above the measured one; the measured number falls inside the stated range.
By their numbers in this assay, from the lowest: compounds 1, 4, 3 and 2 (each within the scatter of the next, the first and the last beyond it).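

In this assay, 4-hydroxypiperidin-1-yl on the shorter chain in place of the dimethylamino-ended chain gives a 2.7-fold lower number from compound 2 to compound 4 (0.44 log units; beyond the scatter) and so moves beyond the scatter, while the same kind of exchange against the longer chain gives a 1.5-fold lower number from compound 3 to compound 4 (0.18 log units; within the scatter) and does not. The change of head therefore separates compound 4 only from compound 2, and both steps alter chain length together with the amine. No measurement shown explains either step.

Still open, going by these compounds, is what the hydroxyl contributes, which unsubstituted piperidin-1-yl on the same chain would address. Dimethylamino on this shorter chain would separate the amine from chain length.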